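Flipping one ring stereocentre on the amide substituent

The source may hold more compounds than are shown below. What is called first, only, known or untested is meant among the compounds shown, and "the series" means these compounds.

Of the compounds shown here, three sharing one core have been measured in an assay on CHO cells for agonist activity at Neuronal acetylcholine receptor; alpha3/alpha6/beta2/beta3 (Homo sapiens), read by FLIPR and calcium flux; a lower number here means a smaller maximal response, a higher number a larger maximal response. Compound 1 `CC(C)C(=O)N1CC2CC(C1)N2` carries an isopropyl on the carbonyl carbon and gives 45%. Compound 2 `O=C([C@H]1C[C@H]1F)N1CC2CC(C1)N2` has a 2-fluorocyclopropyl in that place and gives 130%, so a number 85 percentage points higher from compound 1 to compound 2 (beyond the scatter). Compound 3 `C[C@@H]1C[C@@H]1C(=O)N1CC2CC(C1)N2` carries a methyl on a saturated ring carbon of the cyclopropyl and gives 87%; here a number 42 percentage points higher from compound 1 to compound 3 (beyond the scatter), whereas a number 43 percentage points lower from compound 2 to compound 3 (beyond the scatter). Among the three values compound 3 stands second highest, nearest to compound 1 and furthest from compound 2.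

Compound 4 `C[C@@H]1C[C@H]1C(=O)N1CC2CC(C1)N2` is the next step: the two compounds have the same atoms and bonds; at least one stereo element is drawn with a configuration in one of them and without one in the other: 1 of 4 stereo elements differ; a stereocentre at a saturated ring carbon is drawn S in compound 3 and R in compound 4. Among the measured compounds shown here, every measured step so far exchanged one group for another on the carbonyl carbon or on the ring; none of them changed only a stereocentre, so no step bears directly on this change. The three results do show that the size and shape of the group on the carbonyl carbon move the maximal response by large amounts, which leaves room for a real shift in either direction. With no direct guide, the expectation for compound 4 rests on compound 3 and is a number 2 percentage points lower from compound 3 to compound 4 (within the scatter), that is, compound 4 is estimated at 85% with a range from 50% to 120%.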

Compound 4, largest response reached (Emax), in percent of the reference or control that the assay uses: 110%
Estimate against measurement, compound 4: 25 percentage points below, and the stated range covers the measured number.
By their numbers in this assay, from the lowest: compound 1; then compound 3; then compound 4; then compound 2.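

In this assay, among the compounds shown here, a number 23 percentage points higher from compound 3 to compound 4 (beyond the scatter), the first step here that touches only a stereocentre. Atoms and bonds stay the same, yet the configuration at one saturated ring carbon of the cyclopropyl is enough to move the maximal response beyond the scatter, so the 2-methylcyclopropyl group cannot be treated as a single entity with a single value. The comparisons with the other groups depend on the configuration too: a number 65 percentage points higher from compound 1 to compound 4 (beyond the scatter), against a number 42 percentage points higher from compound 1 to compound 3 (beyond the scatter), and a number 20 percentage points lower from compound 2 to compound 4 (beyond the scatter), against a number 43 percentage points lower from compound 2 to compound 3 (beyond the scatter). One caution applies to how firmly the stereocentre step can be read as a swap between two defined forms: the fact that one of compounds 3 and 4 is drawn with a defined configuration and the other without, at the place where they differ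

Going by these compounds, the 2-fluorocyclopropyl group appears in only one drawn form, so it remains open whether flipping the matching stereocentre would shift its response in the same direction or by a similar amount. Also open, on these data alone, is what a chloro or an ethyl on that ring carbon would give, and whether configuration would matter as much for those groups.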